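Carboxylic acid in place of the propyl amide of compound 1

This account rests on a few compounds, and the source may have more. Where it says the series, first, only, none or still open, it means among the compounds named here.

Compound 1 `C=CC1=C(C(=O)NCCC)C(c2ccc(F)cc2)OC1` was tested in a functional assay on HeLa cells (Homo sapiens) for cytotoxicity, read by MTT assay, with a stated time of 24 h; on this read-out lower numbers stand for stronger inhibition and higher numbers for weaker inhibition. In this assay compound 1 gives > 100000 nM, which is a limit of the assay rather than a number. Compound 2 `C=CC1=C(C(=O)NCc2ccccc2)C(c2ccc(OC)c(OC)c2)OC1` gives > 100000 nM in this assay, also a limit. Compound 3 `C=CC1=C(C(=O)NCc2ccc(C)cc2)C(c2ccc(F)cc2)OC1` gives > 100000 nM in this assay, again a limit. The step that the two limits leave unreadable from compound 1 to compound 3 is therefore unreadable in size, and all values shown sit at the limit of > 100000 nM in this assay, at which 3 of the 3 values shown sit. Compound 4 `C=CC1=C(C(=O)O)C(c2ccc(F)cc2)OC1` differs from compound 1 by hydroxy in place of propylamino on a carbonyl carbon. Among the measured compounds shown here, no measured step bears on this change, and every measured compound sits at the limit. Compound 4 is therefore expected to stay at the limit, with an expected step that the limit leaves unreadable from compound 1 to compound 4, none beyond the scatter. Compound 4 is estimated at 150000 nM, between 50000 nM and 500000 nM.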

Compound 4, half-maximal inhibitory concentration: 67400 nM
For compound 4 the middle estimate is 2.2-fold (0.35 log units) above the measured one, and the stated range covers the measured number.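

Among the compounds shown here, compound 4 is the first compound to give a number rather than a limit, so the carbonyl carbon is the first place where a change yields a readable value. In this assay, hydroxy in place of propylamino gives an at least 1.4-fold lower number from compound 1 to compound 4 (0.17 log units; that floor lies within the scatter). The floor of this step does not establish a change beyond the scatter, and the other values offer no number to compare: the limit of > 100000 nM in this assay, at which 3 of the 4 values shown sit.

On these data alone, it remains open whether a methyl ester or a primary amide at this carbonyl carbon would also give a number.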